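Aryl Groups in Place of an Alkynol: Microsomal Clearance

This account rests on a few compounds, and the source may have more. Where it says the series, first, only, none or still open, it means among the compounds named here.

Measured compounds:
Compound 1 `CC(C)(O)C#Cc1cc(C(O)(C(F)(F)F)C(F)(F)F)cnc1N1CCN(S(=O)(=O)c2ccc(N)nc2)CC1` gives 16 mL.min-1.g-1
Compound 2 `Nc1ccc(S(=O)(=O)N2CCN(c3ncc(C(O)(C(F)(F)F)C(F)(F)F)cc3-c3ccncc3)CC2)cn1` gives 31 mL.min-1.g-1
Compound 3 `Cc1ccc(-c2cc(C(O)(C(F)(F)F)C(F)(F)F)cnc2N2CCN(S(=O)(=O)c3ccc(N)nc3)CC2)cn1` gives 182 mL.min-1.g-1

These three compounds share one core and differ only in the group carried on an aromatic carbon of the core. Those values come from an ADME assay (liver) for metabolic stability, with Liver microsome (Rattus norvegicus) as the target, using microsomes and NADPH, with a stated time of 30 min, tested at 1 uM; on this read-out lower numbers stand for slow clearance and higher numbers for fast clearance. Compound 1 stands lowest of the three numbers, though its gap to compound 2 is within the scatter, so the two cannot be ordered; its gap to compound 3 is large and clear.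

The steps that matter are a 1.9-fold higher number from compound 1 to compound 2 (0.29 log units; within the scatter) and an 11-fold higher number from compound 1 to compound 3 (1.06 log units; beyond the scatter); the third, a 5.9-fold higher number from compound 2 to compound 3 (0.77 log units; beyond the scatter), shows that the identity of the entering ring changes the outcome considerably.

Compound 4 `Nc1ccc(S(=O)(=O)N2CCN(c3ncc(C(O)(C(F)(F)F)C(F)(F)F)cc3-c3ccc4c(c3)CC(=O)N4)CC2)cn1` carries the change (a group of 10 heavy atoms (8 carbon, 1 nitrogen, 1 oxygen; one five-membered non-aromatic ring with 1 hetero atom, one six-membered aromatic ring of carbon only) in place of a group of 6 heavy atoms (5 carbon, 1 oxygen; no ring), on an aromatic carbon). Both measured replacements of the 3-hydroxy-3-methylbut-1-yn-1-yl group by a ring gave higher numbers, one within the scatter and one far beyond it. A ring again enters here, this time a larger one with a five-membered non-aromatic ring fused to it, for which no measured neighbour exists. A rise in this assay is therefore expected, most likely beyond the scatter but short of the largest step seen, giving an estimated 3.8-fold higher number from compound 1 to compound 4 (0.57 log units; beyond the scatter). Compound 4 is thus expected to give about 60 mL.min-1.g-1, within 25 mL.min-1.g-1 to 150 mL.min-1.g-1.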

Compound 4, intrinsic clearance in microsomes: 119 mL.min-1.g-1
Compound 4: the middle estimate sits 2.0-fold (0.30 log units) below what was measured; measured number inside the range.
By their numbers in this assay, from the lowest: compounds 1 and 2 (each within the scatter of the next); then compounds 4 and 3 (each within the scatter of the next).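

Moving from the 3-hydroxy-3-methylbut-1-yn-1-yl group to the new group, which has a five-membered non-aromatic ring and a six-membered aromatic ring of carbon only, gives a 7.4-fold higher number from compound 1 to compound 4 (0.87 log units; beyond the scatter) in this assay, so two of the three ring-bearing groups at this position now lie clearly beyond the scatter from compound 1, while compound 2 goes against that trend. The new group also separates from pyridin-4-yl with a 3.8-fold higher number from compound 2 to compound 4 (0.58 log units; beyond the scatter) but not from 6-methylpyridin-3-yl with a 1.5-fold lower number from compound 3 to compound 4 (0.18 log units; within the scatter) and this leaves compound 3 and compound 4 unordered even though their groups differ in size and ring type, so compound 2 alone among the ring-bearing compounds stays close to compound 1. Nothing available here explains why these groups behave differently.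

As far as these compounds go, it remains open which part of the new group matters, since a plain phenyl ring, or the same two rings without the carbonyl, would be needed to tell. Also open, from the compounds shown here alone, is how a small amine or a longer chain ending in a carboxylic acid would compare with compound 1 at this position.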